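The source may hold more compounds than are shown below. What is called first, only, known or untested is meant among the compounds shown, and "the series" means these compounds.

The shared core of these compounds is the same throughout; they differ only in the small aromatic ring that sits para to a large group on the benzyl part. Compound 1 `Cc1cc(C)c(NC(=O)N(Cc2ccc(-c3cccs3)cc2)C2CCCCCC2)c(C)c1` carries a thiophen-2-yl there, and in a functional assay on a cell-free system (plasma) with sterol O-acyltransferase, Soat (Rattus norvegicus) as the target (a lower number here means that less compound is needed, a higher number that more compound is needed for the effect), compound 1 gives 0.28 mg/kg. Compound 2 `Cc1cc(C)c(NC(=O)N(Cc2ccc(-c3cccnc3)cc2)C2CCCCCC2)c(C)c1` carries a pyridin-3-yl, and in this assay compound 2 gives 0.58 mg/kg; this is a 2.1-fold higher number from compound 1 to compound 2 (0.32 log units; beyond the scatter). Compound 3 `Cc1cc(C)c(NC(=O)N(Cc2ccc(-c3cc[nH]n3)cc2)C2CCCCCC2)c(C)c1` carries a 1H-pyrazol-3-yl. In this assay compound 3 reaches only a limit of the assay, > 1 mg/kg, which is the limit of > 1 mg/kg in this assay, at which 1 of the 3 values shown sits. This gives an at least 3.5-fold higher number from compound 1 to compound 3 (0.55 log units; beyond the scatter) and an at least 1.7-fold higher number from compound 2 to compound 3 (0.23 log units; that floor lies within the scatter). Compound 4 `Cc1cc(C)c(NC(=O)N(Cc2ccc(-n3ccnn3)cc2)C2CCCCCC2)c(C)c1` makes the change (1H-1,2,3-triazol-1-yl in place of 1H-pyrazol-3-yl on an aromatic carbon). Among the measured compounds shown here, no measured step covers this exact exchange; the nearest, each swap of the thiophen-2-yl for a nitrogen-containing ring, raised the dose. In this assay compound 4 is therefore expected to stay around the limit, about a step that the limit leaves unreadable from compound 3 to compound 4. The estimate for compound 4 in this assay is 1.5 mg/kg, within a range from 0.6 mg/kg to 4 mg/kg.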

Compound 4, dose for half-maximal effect: > 1 mg/kg
Compound 4: only a limit was reported; the forecaster's own chance of this, stated with the estimate: 65%; the middle value lies beyond the limit too.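

In this assay compound 4 stops at a limit of the assay rather than at a number, the same outcome as compound 3: the limit of > 1 mg/kg in this assay, at which 2 of the 4 values shown sit. The 1H-1,2,3-triazol-1-yl has no hydrogen-bond donor, so a nitrogen-rich five-membered ring without one also fails to give a readable dose here, although the step between the two limits cannot be read. Against the other rings, the result gives an at least 3.5-fold higher number from compound 1 to compound 4 (0.55 log units; beyond the scatter), while it gives an at least 1.7-fold higher number from compound 2 to compound 4 (0.23 log units; that floor lies within the scatter), so only the gap to the thiophen-2-yl is clear.

On these data alone, how far compound 3 and compound 4 lie past the limit stays open. The compounds shown also leave open whether a plain phenyl ring or a thiophen-3-yl at this position would need a dose as low as compound 1 does.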